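The source may hold more compounds than are shown below. What is called first, only, known or untested is meant among the compounds shown, and "the series" means these compounds.

Compound 1 `O=C(Nc1cccc(S(F)(F)(F)(F)F)c1)c1ccc(Sc2ccc(O)cc2)cc1` and compound 2 `O=C(Nc1cccc(C(F)(F)F)c1)c1ccc(Sc2ccc(O)cc2)cc1` share one core and differ in a single group. In a functional assay on VCaP cells (Homo sapiens) for antiproliferative activity, read by fluorescence and propidium iodide staining, with a stated time of 96 h (a higher number here means a weaker inhibitor, a lower number a stronger inhibitor), compound 1 gives 6100 nM, and compound 2 gives 10600 nM. The difference between them is a group of 4 heavy atoms (1 carbon, 3 fluorine; no ring) in place of a group of 6 heavy atoms (5 fluorine, 1 sulfur; no ring), on an aromatic carbon, and it made a step of a 1.7-fold higher number from compound 1 to compound 2 (0.24 log units; within the scatter). Compound 3 `O=C(Nc1ccc(S(F)(F)(F)(F)F)cc1)c1ccc(S(=O)(=O)c2ccc(O)cc2)cc1` is built on a different core, and the difference between the two cores is not broken down here. In this assay compound 3 gives 5350 nM. Compound 4 `O=C(Nc1ccc(C(F)(F)F)cc1)c1ccc(S(=O)(=O)c2ccc(O)cc2)cc1` has not been measured. It differs from compound 3 by a group of 4 heavy atoms (1 carbon, 3 fluorine; no ring) in place of a group of 6 heavy atoms (5 fluorine, 1 sulfur; no ring), on an aromatic carbon. Going by the values given here, this is the same kind of change as the one from compound 1 to compound 2, not the same one: in the first pair the group sits meta to a large group, in the second pair para to a large group, and the cores differ as well. The step from compound 3 to compound 4 is expected to be about a 1.7-fold higher number from compound 3 to compound 4 (0.23 log units; within the scatter), resting on the measured step of a 1.7-fold higher number from compound 1 to compound 2 (0.24 log units; within the scatter) and allowing for the changed surroundings. Compound 4 is therefore expected to give 9000 nM in this assay, estimated to fall between 4000 nM and 20000 nM.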

Compound 4, half-maximal inhibitory concentration: 27200 nM
Compound 4: middle estimate off by 3.0-fold (0.48 log units), on the low side; the measured number lies above the stated range.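

In this assay, putting trifluoromethyl in place of the sulfur-and-fluorine group gives a 5.1-fold higher number from compound 3 to compound 4 (0.71 log units; beyond the scatter), and this does not match the same change made on the other core: the same change on two cores in this assay, a 1.7-fold higher number (0.24 log units; within the scatter) from compound 1 to compound 2 and a 5.1-fold higher number (0.71 log units; beyond the scatter) from compound 3 to compound 4, 2.9-fold (0.47 log units) apart, beyond the scatter of two such steps. Going by these compounds alone, the size of this step therefore cannot simply be carried from one core to another, and only the step on the core of compound 3 stands clear of the scatter. The result does not show what causes the gap, as the two pairs differ both in their core and in where the group sits on its ring, and two pairs cannot establish a general rule.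

As far as these compounds go, it remains open whether the gap follows the core or the position of the group, which only a pair differing in just one of these could settle. From the compounds shown here alone, it also remains open how other groups in the same place, such as a nitrile or an amine, would compare with these two.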